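Swapping the aryl group on the hydrazone of compound 3

A few compounds are considered here, and "the series" means these few. Any claim that something is new, unique, unknown or untested is made for them only; others in the source may bear on it.

Among the compounds with values here, in a functional assay on HCT-116 cells (Homo sapiens) for antiproliferative activity, read by MTT assay (on this read-out lower numbers stand for stronger inhibition and higher numbers for weaker inhibition), compound 3 `Cn1c(=O)c(=O)n(C2CCCC2)c2nc(N/N=C/c3ccccc3F)ncc21` gives 20700 nM, the second highest of the three numbers known. Compound 2 `Cc1cc(C)c(/C=N/Nc2ncc3c(n2)n(C2CCCC2)c(=O)c(=O)n3C)c(C)c1` gives 7920 nM, and compound 1 `Cn1c(=O)c(=O)n(C2CCCC2)c2nc(N/N=C/c3ccc(O)c(F)c3)ncc21` gives 59300 nM. The steps among them are all modest: a 7.5-fold lower number from compound 1 to compound 2 (0.87 log units; beyond the scatter), a 2.9-fold lower number from compound 1 to compound 3 (0.46 log units; beyond the scatter) and a 2.6-fold higher number from compound 2 to compound 3 (0.42 log units; beyond the scatter). Compound 4 `Cn1c(=O)c(=O)n(C2CCCC2)c2nc(N/N=C/c3cc([N+](=O)[O-])ccc3Cl)ncc21` has not been measured in this assay. It differs from compound 3 in one place: 2-chloro-5-nitrophenyl in place of 2-fluorophenyl on a carbon with a double bond to nitrogen. Within the data shown here, no measured step covers a nitro or chloro group at this position, so only the general size of aryl swaps here bears on it, and those moved the number by at most the step from compound 1 to compound 2. A modest step, in either direction, is therefore the most that is expected, with a slight lean toward a lower number given that the aryl swaps so far all left compound 1 as the highest. Compound 4 is expected to give 13000 nM in this assay, within 4000 nM to 45000 nM, which is an estimated step of a 1.6-fold lower number from compound 3 to compound 4 (0.20 log units; within the scatter).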

Compound 4, half-maximal inhibitory concentration: 5610 nM
Compound 4: middle estimate off by 2.3-fold (0.36 log units), on the high side, within the range that was stated.
By their numbers in this assay, from the lowest: compounds 4 and 2 (each within the scatter of the next); then compound 3; then compound 1.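

In this assay, placing 2-chloro-5-nitrophenyl on the carbon with a double bond to nitrogen gives a 3.7-fold lower number from compound 3 to compound 4 (0.57 log units; beyond the scatter) and so shows that replacing the 2-fluorophenyl group at this position can lower the number. Against the 2,4,6-trimethylphenyl group, the new group gives a 1.4-fold lower number from compound 2 to compound 4 (0.15 log units; within the scatter) within the scatter, so these two differently substituted aryl groups cannot be told apart here. Within the data shown here, the span across the position also grows, with an 11-fold lower number from compound 1 to compound 4 (1.02 log units; beyond the scatter) as the only large step so far, and the 3-fluoro-4-hydroxyphenyl group remains at the high end.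

No evidence at hand explains these steps. The compounds shown leave open whether the chloro or the nitro group alone carries the step, and how an amine or a carboxylic acid on the ring would compare.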